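Aryl ketone variation on the shared core: antiproliferative readings

The compounds below may be only part of what the source reports. "The series", "measured", "known", "first", "only" and "open" are said of these compounds alone.

Measured so far:
compound 1 `COc1cc(-c2nnc(SCC(=O)c3ccc(Cl)cc3)n2N)cc(OC)c1OC` — > 100000 nM
compound 2 `COc1cc(-c2nnc(SCC(=O)c3ccc(F)cc3)n2N)cc(OC)c1OC` — 90400 nM

In a functional assay on HepG2 cells (Homo sapiens) for antiproliferative activity, read by MTT assay, with a stated time of 48 h (a higher number here means a weaker inhibitor, a lower number a stronger inhibitor), compound 1 gives > 100000 nM, which is a limit of the assay and not a number. Compound 2, with fluoro in place of chloro on an aromatic carbon, gives 90400 nM in this assay; the step of an at least 1.1-fold lower number from compound 1 to compound 2 (0.04 log units; that floor lies within the scatter) sits at the limit of > 100000 nM in this assay, at which 1 of the 2 values shown sits, and within the scatter. Compound 3, `COc1cc(-c2nnc(SCC(=O)c3cccc(Br)c3)n2N)cc(OC)c1OC`, differs from compound 1 by 3-bromophenyl in place of 4-chlorophenyl on a carbonyl carbon. Among the compounds with values here, only that one measured step bears on the change, and it shows no movement beyond scatter, so a step of about a number no higher from compound 1 to compound 3 (the limit leaves the size open) is expected, with no clear direction. Compound 3 is therefore estimated at 100000 nM, between 30000 nM and 300000 nM, likely again reported only as a limit.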

Compound 3, half-maximal inhibitory concentration: 56000 nM
Compound 3: middle estimate off by 1.8-fold (0.25 log units), on the high side, within the range that was stated.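

With 3-bromophenyl in place of 4-chlorophenyl on the carbonyl carbon, the series shows an at least 1.7-fold lower number from compound 1 to compound 3 (0.25 log units; that floor lies within the scatter). The reading for compound 1 is a limit of the assay and not a number, so the size of this step stays open: the limit of > 100000 nM in this assay, at which 1 of the 3 values shown sits.

The step between two actual numbers is a 1.6-fold lower number from compound 2 to compound 3 (0.21 log units; within the scatter), so exchanging these aryl groups on the carbonyl carbon shows no movement beyond scatter.

Still open, going by these compounds, is whether a 4-bromophenyl group reads apart from 3-bromophenyl. Also open, on these data alone, is whether an amine or a carboxylic acid on the phenyl ring moves the reading beyond scatter.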